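This account rests on a few compounds, and the source may have more. Where it says the series, first, only, none or still open, it means among the compounds named here.

Among the compounds with values here, compound 2 `Cc1ccc(Cn2c(/C=C3\SC(=S)N(CC(=O)O)C3=O)nc3ccccc32)cc1` gives the lowest of the two numbers measured so far in a functional assay on HL-60 cells (Homo sapiens) for cytotoxicity, read by MTT assay, with a stated time of 48 h (a lower number here means a stronger inhibitor, a higher number a weaker inhibitor), where compound 2 gives 540 nM; compound 1 `N#Cc1ccc(Cn2c(/C=C3\SC(=S)N(CC(=O)O)C3=O)nc3ccccc32)cc1` gives 7640 nM. Within the data shown here, the one measured step, a 14-fold lower number from compound 1 to compound 2 (1.15 log units; beyond the scatter), shows that the group on the benzyl ring matters. Compound 3 `O=C(O)CN1C(=O)/C(=C/c2nc3ccccc3n2Cc2ccc(F)c(F)c2)SC1=S` carries 3,4-difluorophenyl in place of 4-methylphenyl on a saturated chain carbon bound to an aromatic nitrogen. Among the measured compounds shown here, no step with two fluorines is known, so the size is uncertain; the only measured step bears on it loosely, and a modest weakening, a 2.8-fold higher number from compound 2 to compound 3 (0.44 log units; beyond the scatter), is expected. The estimate for compound 3 in this assay is 1500 nM, with a range from 500 nM to 5000 nM.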

Compound 3, half-maximal inhibitory concentration: 2740 nM
Compound 3: middle estimate off by 1.8-fold (0.26 log units), on the low side; the measured number falls inside the stated range.
By their numbers in this assay, from the lowest: compound 2; then compound 3; then compound 1.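

Replacing the group at this position gives a 5.1-fold higher number from compound 2 to compound 3 (0.71 log units; beyond the scatter) in this assay, while the same group gives a 2.8-fold lower number from compound 1 to compound 3 (0.45 log units; beyond the scatter). The 3,4-difluorophenyl group therefore falls between the other two: it is weaker than 4-methylphenyl but stronger than 4-cyanophenyl, so these changes produce a graded order rather than a simple split into active and inactive compounds. Nothing available here explains this order. Going by these compounds, it remains open whether a single fluorine, a methoxy group or an amine on the benzyl ring would give a number nearer that of compound 2 or that of compound 1 .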